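This account rests on a few compounds, and the source may have more. Where it says the series, first, only, none or still open, it means among the compounds named here.

Measured compounds:
- compound 1, `CC(=O)NC12CCCC3CC(CCC31)C2`: 3000000 nM
- compound 2, `C1=C2CCCC3CC1CCC23`: no result reported
- compound 3, `O[C@@H]1C2CCCC3C[C@@H]1CC[C@@H]32`: 750000 nM

In an ADME assay (Gallus gallus) for cytotoxicity, read by microscopy, with a stated time of 24 h (a lower number here means that less compound is tolerated, a higher number that more compound is tolerated), compound 1 gives 3000000 nM, which is the higher of the two numbers recorded. Compound 3 gives 750000 nM in this assay, and its number lies below that of compound 1 by a gap beyond the usual scatter of repeated measurements. Compound 2 has no result in this assay, so it gives no guidance on the numbers.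

The next compound is compound 4, `COC(=O)C12CCCC3CC(CCC31)C2`. It differs from compound 1 in one place: methoxycarbonyl in place of acetamido on a saturated ring carbon. The change therefore swaps one small group for another of the same size on the shared core, on a saturated ring carbon of a six-membered non-aromatic ring of carbon only.

For the measured compounds named here, no step between measured compounds shows what such a swap does in this assay, and the two numbers recorded span only one comparison. The step of a 1.5-fold lower number from compound 1 to compound 4 (0.18 log units; within the scatter) is expected to be small, within or close to the scatter, since compound 1 gives 3000000 nM and the change keeps the size of the group. Compound 4 is expected to give about 2000000 nM in this assay, with a range from 500000 nM to 6000000 nM.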

Compound 4, minimum cytotoxic concentration: 80000 nM
The estimate for compound 4 lay 25-fold (1.40 log units) above the measured number; the measured number lies below the stated range.
By their numbers in this assay, from the lowest: compound 4; then compound 3; then compound 1.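

In this assay putting methoxycarbonyl in place of acetamido on a saturated ring carbon gives a 38-fold lower number from compound 1 to compound 4 (1.57 log units; beyond the scatter) and marks a large drop in the amount of compound tolerated. This position on the shared core is therefore sensitive to the identity of its group, even though both groups have 4 heavy atoms, no ring and no net charge, so matching the heavy-atom count does not keep the number in place. The counted differences are that acetamido brings nitrogen, 1 hydrogen-bond donor and 1 hydrogen-bond acceptor, whereas methoxycarbonyl brings 0 hydrogen-bond donors and 2 hydrogen-bond acceptors, but no measurement here explains the step or links it to any one of these differences.

This single step cannot separate the loss of the donor from the change in the atoms themselves, and a primary amine or a carboxylic acid on the same ring carbon would give further points for comparison. Going by these compounds, it also remains open whether a longer chain at this position would move the number as far as this swap did.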